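The compounds below may be only part of what the source reports. "The series", "measured", "known", "first", "only" and "open" are said of these compounds alone.

In a functional assay on M21 cells (Homo sapiens) for antiproliferative activity, read by sulforhodamine B assay, with a stated time of 48 h (on this read-out lower numbers stand for stronger inhibition and higher numbers for weaker inhibition), compound 1 (`CCCN1CCN(c2ccc(S(=O)(=O)Oc3ccccc3CC)cc2)C1=O`) gives > 50000 nM as its reading, and this is a limit of the assay rather than a number. Compound 2 (`CCCN1CCN(c2ccc(S(=O)(=O)Oc3cccc(OC)c3)cc2)C1=O`) reads 10000 nM and compound 3 (`CCCN1CCN(c2ccc(S(=O)(=O)Oc3cccc(Cl)c3)cc2)C1=O`) reads 8600 nM in the same test. These two readings stand level, since the step is a 1.2-fold lower number from compound 2 to compound 3 (0.07 log units; within the scatter) and shows no real gap. Compound 4 (`CCCN1CCN(c2ccc(S(=O)(=O)Oc3ccc(F)cc3)cc2)C1=O`) has not yet been measured. It carries 4-fluorophenyl in place of 3-chlorophenyl on an oxygen whose other neighbour is the sulfonyl sulfur (4-fluorophenyl in place of 3-chlorophenyl on an oxygen). Within the data shown here, the steps that bear on this swap are those that change the same group. Going to 3-methoxyphenyl from 2-ethylphenyl gave an at least 5.0-fold lower number from compound 1 to compound 2 (0.69 log units; beyond the scatter) and going to 3-chlorophenyl gave an at least 5.8-fold lower number from compound 1 to compound 3 (0.76 log units; beyond the scatter) in turn. Among the measured compounds shown here, no measured compound carries 4-fluorophenyl, so the guide is only indirect. For the measured compounds named here, with a 1.2-fold lower number from compound 2 to compound 3 (0.07 log units; within the scatter) as the closest precedent, no step beyond the scatter is expected in this assay here. The expected step is a 1.2-fold higher number from compound 3 to compound 4 (0.07 log units; within the scatter) with wide uncertainty. For compound 4 the estimated value is 10000 nM with an expected range of 3000 nM to 35000 nM in this test.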

Compound 4, half-maximal inhibitory concentration: 14000 nM
For compound 4 the middle estimate is 1.4-fold (0.15 log units) below the measured one, and the stated range covers the measured number.
By their numbers in this assay, from the lowest: compounds 3, 2 and 4 (each within the scatter of the next). At a limit, above all of these: compound 1.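

In this assay, 4-fluorophenyl in place of 3-chlorophenyl on the oxygen whose other neighbour is the sulfonyl sulfur gives a 1.6-fold higher number from compound 3 to compound 4 (0.21 log units; within the scatter), and 4-fluorophenyl in place of 3-methoxyphenyl gives a 1.4-fold higher number from compound 2 to compound 4 (0.15 log units; within the scatter), so three different groups at this place now stand level. The 2-ethylphenyl group stays apart from all three, now also by an at least 3.5-fold lower number from compound 1 to compound 4 (0.55 log units; beyond the scatter). Compound 1 gives a limit of the assay, not a number, so the true size of that step stays unknown: the limit of > 50000 nM in this assay, at which 1 of the 4 values shown sits.

From the compounds shown here alone, whether 3-fluorophenyl or 4-chlorophenyl would read like these three remains open, so the halogen and its place on the ring cannot be told apart here. Also open, going by these compounds, is whether a phenyl ring carrying an amine or a carboxylic acid at this oxygen would read any differently in this assay.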